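Series notes: group swap on the amide-type nitrogen, cytotoxicity

The compounds below may be only part of what the source reports. "The series", "measured", "known", "first", "only" and "open" are said of these compounds alone.

The shared core is that of compound 1 `CC1=CC[C@@H]([C@@](C)(O)CCCC(C)(C)NC(=S)NN)CC1`. In a functional assay on NCI-H460 cells (Homo sapiens) for cytotoxicity, read by sulforhodamine B assay (a higher number here means that more compound is tolerated, a lower number that less compound is tolerated), compound 1 gives only a limit of the assay, > 100000 nM. Compound 2 `CC1=CC[C@@H]([C@@](C)(O)CCCC(C)(C)NC(=S)N/N=C\c2ccccc2Cl)CC1` carries a step that the two limits leave unreadable from compound 1 to compound 2. In this assay compound 2 likewise reaches only a limit, > 100000 nM. Compound 2 therefore stands at the limit of > 100000 nM in this assay, at which 2 of the 2 values shown sit, and no number places it more closely. Compound 3 `CC1=CC[C@@H]([C@@](C)(O)CCCC(C)(C)NC(=S)N/N=C(/C)c2ccccc2)CC1` differs from compound 2 by a group of 9 heavy atoms (8 carbon, 1 nitrogen; one six-membered aromatic ring of carbon only) in place of a group of 9 heavy atoms (7 carbon, 1 nitrogen, 1 chlorine; one six-membered aromatic ring of carbon only), on an amide-type nitrogen. Going by the values given here, the only measured step, from compound 1 to compound 2, runs between two limits and has no readable size, so no measured step gives a magnitude for the change from compound 2 to compound 3. Because compound 2 sits at the limit of > 100000 nM in this assay, at which 2 of the 2 values shown sit, the expected step to compound 3 in this assay is none beyond the scatter, a number no higher from compound 2 to compound 3 (the limit leaves the size open). Compound 3 is accordingly estimated at 100000 nM, within 30000 nM to 300000 nM, most probably reported again only as a limit.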

Compound 3, concentration lethal to 50% of the cells: > 100000 nM
Compound 3 was reported as a limit (the forecaster's own chance of this, stated with the estimate: 80%); the middle value lies on the limit itself.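

Compound 3 gives only a limit in this assay, > 100000 nM. Going by these compounds alone, no step among compound 1, compound 2 and compound 3 can be read. The compounds shown leave open whether the group on the amide-type nitrogen changes cytotoxicity at all, and at what concentration any of them would reach the read-out.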